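Replacing the Furan on Compound 2 with Aminomethylphenyl

The compounds below may be only part of what the source reports. "The series", "measured", "known", "first", "only" and "open" are said of these compounds alone.

Three hydroxamic acids have been measured in an assay on Sf9 cells for inhibition of protein deacetylase HDAC6 (Homo sapiens), read by fluorescence; a higher number here means a weaker inhibitor, a lower number a stronger inhibitor. Compound 2 `O=C(NO)c1cc(F)c(Cn2nnc(-c3ccco3)n2)c(F)c1` gives 3 nM, the lowest of the three numbers. Its nearest neighbour is compound 1 `O=C(NO)c1ccc(Sc2nnc(-c3ccccc3)s2)cc1`, which in this assay gives 6 nM, a number that lies within the scatter of compound 2, so the two cannot be ranked against each other. The furthest is compound 3 `O=C(NO)c1ccc(Nc2nnc(-c3ccccc3)o2)cc1`, which gives 136 nM, a number well beyond the scatter from compound 2.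

Compound 4 `NCc1ccc(-c2nnn(Cc3c(F)cc(C(=O)NO)cc3F)n2)cc1` has not yet been measured. It differs from compound 2 in one place: 4-(aminomethyl)phenyl in place of furan-2-yl on an aromatic carbon. The hydroxamic acid and the rest of the core of compound 2 are kept.

Going by the values given here, no pair of measured compounds differs in a single place, so there is no directly comparable step to lean on, and the spread among compounds 1, 2 and 3 is the only guide to how far a change of this kind can move the number. The author expects a modest step towards a higher number, possibly none beyond the scatter, since the whole hydroxamic acid part that compound 2 shares with compound 4 is untouched. Compound 4 is therefore estimated at 7 nM, with a likely range from 2 nM to 25 nM. The expected step is a 2.3-fold higher number from compound 2 to compound 4 (0.37 log units; beyond the scatter).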

Compound 4, half-maximal inhibitory concentration: 4 nM
Compound 4: middle estimate off by 1.8-fold (0.24 log units), on the high side; low and high end bracket the measured number.
By their numbers in this assay, from the lowest: compounds 2, 4 and 1 (each within the scatter of the next); then compound 3.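

In this assay, going by these compounds alone, the exchange of furan-2-yl for 4-(aminomethyl)phenyl on the aromatic carbon between two ring nitrogen atoms gives a 1.3-fold higher number from compound 2 to compound 4 (0.12 log units; within the scatter), the first step in this set that isolates a change in one place. The earlier compounds shown here differed in more than one place and could not show what this carbon tolerates, whereas this step shows that a group of 8 heavy atoms, with a six-membered aromatic ring of carbon only and 1 hydrogen-bond donor, can take the place of a five-membered aromatic ring of 5 heavy atoms with no difference that can be told from the scatter. Nothing measured here accounts for how closely the two numbers agree.

From the compounds shown here alone, what a plain phenyl, a 4-(hydroxymethyl)phenyl or a 4-(2-aminoethyl)phenyl group would give on the same carbon stays open, so the part played by the amine in this step cannot be separated from that of the six-membered ring. Nor do the compounds shown tell whether a carboxylic acid at the end of that ring would be accepted equally well.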